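Replacing 2-nitrophenyl with 4-hydroxy-3-methoxyphenyl on the shared core

The compounds below may be only part of what the source reports. "The series", "measured", "known", "first", "only" and "open" are said of these compounds alone.

In a functional assay on DU-145 cells (Homo sapiens) for cytotoxicity, read by sulforhodamine B assay, with a stated time of 48 h (on this read-out higher numbers stand for weaker inhibition and lower numbers for stronger inhibition), compound 1 `C[C@H]1CC[C@@H]2[C@@H](OC(=O)[C@]23CC(c2ccccc2Br)=NO3)[C@]2(C)C(=O)C=C[C@@]12O` gives 18000 nM, compound 2 `C[C@H]1CC[C@@H]2[C@@H](OC(=O)[C@]23CC(c2ccc(O)cc2)=NO3)[C@]2(C)C(=O)C=C[C@@]12O` gives 93000 nM, and compound 3 `C[C@H]1CC[C@@H]2[C@@H](OC(=O)[C@]23CC(c2ccccc2[N+](=O)[O-])=NO3)[C@]2(C)C(=O)C=C[C@@]12O` gives 34000 nM. Compound 3 thus sits within the scatter of compound 1, as the step of a 1.9-fold higher number from compound 1 to compound 3 (0.28 log units; within the scatter) shows, and under compound 2. Compound 4 `COc1cc(C2=NO[C@]3(C2)C(=O)O[C@@H]2[C@H]3CC[C@H](C)[C@]3(O)C=CC(=O)[C@@]23C)ccc1O` differs from compound 3 as follows: 4-hydroxy-3-methoxyphenyl in place of 2-nitrophenyl on a carbon with a double bond to nitrogen. It has 4-hydroxy-3-methoxyphenyl in place of 2-nitrophenyl. Within the data shown here, the closest guide is compound 2, the only measured 4-hydroxyphenyl member, with the steps of a 5.2-fold higher number from compound 1 to compound 2 (0.71 log units; beyond the scatter) and a 2.7-fold lower number from compound 2 to compound 3 (0.44 log units; beyond the scatter). Among the measured compounds shown here, no measured compound carries the methoxy group. A modest rise is therefore expected, a 2.2-fold higher number from compound 3 to compound 4 (0.34 log units; beyond the scatter). Compound 4 is estimated at 75000 nM, within an expected range of 30000 nM to 170000 nM.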

Compound 4, half-maximal inhibitory concentration: 71000 nM
The estimate for compound 4 lay 1.1-fold (0.02 log units) above the measured number; the range from low to high includes it.
By their numbers in this assay, from the lowest: compounds 1 and 3 (each within the scatter of the next); then compounds 4 and 2 (each within the scatter of the next).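

Adding methoxy to the 4-hydroxyphenyl group barely moves the number (a 1.3-fold lower number from compound 2 to compound 4 (0.12 log units; within the scatter)), which the earlier compounds could not show. The 4-hydroxy-3-methoxyphenyl group stays on the weak side of the series, both against the 2-nitrophenyl group (a 2.1-fold higher number from compound 3 to compound 4 (0.32 log units; beyond the scatter)) and against the 2-bromophenyl group (a 3.9-fold higher number from compound 1 to compound 4 (0.60 log units; beyond the scatter)), so both members bearing a hydroxy group now read above the other two. Nothing available explains these differences. The compounds shown leave open whether an amine or a carboxylic acid in place of the hydroxy group would read as high. They also leave open how a methoxy group without the hydroxy group would read.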